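Oxadiazole replacing the sulfonamide at the pyridine-ring position

This account rests on a few compounds, and the source may have more. Where it says the series, first, only, none or still open, it means among the compounds named here.

Measured so far:
- Compound 1 `CC(C)(C)c1ccc(NC(=O)c2ccc(-c3ccccn3)cc2)cc1`: 11 nM
- Compound 2 `CC(C)(C)c1ccc(NC(=O)c2ccc(-c3ncccc3N(S(C)(=O)=O)S(C)(=O)=O)cc2)cc1`: 0.8 nM
- Compound 3 `CC(C)(C)c1ccc(NC(=O)c2ccc(-c3ncccc3NS(=O)(=O)c3ccccc3)cc2)cc1`: 91 nM

In a functional assay for antagonist activity at transient receptor potential cation channel subfamily V member 1 (Homo sapiens), read by FLIPR (on this read-out higher numbers stand for weaker inhibition and lower numbers for stronger inhibition), compound 3 gives the highest number of the three; compound 1 lies nearest, compound 2 furthest. The step of an 8.3-fold higher number from compound 1 to compound 3 (0.92 log units; beyond the scatter) and the step of a 110-fold higher number from compound 2 to compound 3 (2.06 log units; beyond the scatter) both show that the group on this carbon moves the read-out strongly, while a 14-fold lower number from compound 1 to compound 2 (1.14 log units; beyond the scatter) shows the same position going the other way.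

Compound 4 `Cc1nnc(-c2cccnc2-c2ccc(C(=O)Nc3ccc(C(C)(C)C)cc3)cc2)o1` is the next member: 5-methyl-1,3,4-oxadiazol-2-yl in place of (phenylsulfonyl)amino on an aromatic carbon. Among the measured compounds shown here, no measured compound carries a ring of this kind at that carbon, so the only guide is the range spanned by the three substituents already seen, from hydrogen through the two sulfonamides. The entering group is smaller than the leaving one and has no hydrogen-bond donor, which is closer to the situation of compound 1 and compound 2 than to compound 3. The expectation is therefore a step back toward the numbers of compound 1, estimated as a 7.6-fold lower number from compound 3 to compound 4 (0.88 log units; beyond the scatter), with wide uncertainty because the position has swung as far as a 110-fold higher number from compound 2 to compound 3 (2.06 log units; beyond the scatter) on a single change.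

Compound 4 is expected to give about 12 nM in this assay, within a range of 2 nM to 60 nM.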

Compound 4, half-maximal inhibitory concentration: 387 nM
Compound 4: the middle estimate sits 32-fold (1.51 log units) below what was measured, and the stated range ends below it.
By their numbers in this assay, from the lowest: compound 2; then compound 1; then compound 3; then compound 4.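

In this assay, 5-methyl-1,3,4-oxadiazol-2-yl gives the highest number of the series, with a 4.3-fold higher number from compound 3 to compound 4 (0.63 log units; beyond the scatter); exchanging (phenylsulfonyl)amino for a group with fewer heavy atoms and 0 hydrogen-bond donors therefore does not bring the read-out back toward that of the unsubstituted carbon. The gaps to the other two compounds are wider still, with a 35-fold higher number from compound 1 to compound 4 (1.55 log units; beyond the scatter) and a 480-fold higher number from compound 2 to compound 4 (2.68 log units; beyond the scatter), so the span at this single carbon is larger than the three earlier compounds showed. Of the three groups now seen here, two give higher numbers than hydrogen and only bis(methylsulfonyl)amino in compound 2 goes against that trend, so the low number of compound 2 cannot be read as a general gain from substitution at this carbon.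

The compounds shown leave open how a plain amino group, a single methylsulfonylamino group or a 1,3,4-oxadiazol-2-yl ring without its methyl would fall within this span. The data shown offer no measurement that accounts for the higher number of compound 4.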